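Methoxy for Methyl on a Non-Cytotoxic Imide Scaffold

A few compounds are considered here, and "the series" means these few. Any claim that something is new, unique, unknown or untested is made for them only; others in the source may bear on it.

Compound 1 `CCCCCN1C(=O)C/C(=C\c2cccc(C(=O)Nc3ccc(C)cc3)c2)C1=O` was examined in an ADME assay on NCM460 cells (Homo sapiens) for cytotoxicity, read by MTT assay, with a stated time of 72 h; on this read-out higher numbers stand for weaker inhibition and lower numbers for stronger inhibition. In this assay compound 1 gives > 100000 nM, which is a limit of the assay and not a number. Among the measured compounds shown here, compound 2 `O=C(NCc1ccccc1)c1cccc(/C=C2\CC(=O)N(c3ccccc3)C2=O)c1` is the only other compound with a value here. In this assay compound 2 gives > 100000 nM, again a limit rather than a number. Compound 1 therefore stands at the limit of > 100000 nM in this assay, at which 2 of the 2 values shown sit, and the two values cannot be placed in any order relative to each other. Compound 3 `CCCCCN1C(=O)C/C(=C\c2cccc(C(=O)Nc3ccc(OC)cc3)c2)C1=O` has not yet been measured. It differs from compound 1 by methoxy in place of methyl on an aromatic carbon. For the measured compounds named here, with no step between measured compounds to draw on, no change beyond the usual scatter is expected in this assay, and compound 3 is expected to remain at the limit. Compound 3 is estimated at 150000 nM, with a range from 60000 nM to 400000 nM. The step from compound 1 to compound 3 is expected to be a step that the limit leaves unreadable from compound 1 to compound 3.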

Compound 3, half-maximal inhibitory concentration: > 100000 nM
Compound 3 ended at the assay's limit; the forecaster's own chance of this, stated with the estimate: 85%; the middle value lies beyond the limit too.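

In this assay compound 3 gives > 100000 nM, a limit and not a number. No size can be read for the step between compound 1 and compound 3: the limit of > 100000 nM in this assay, at which 3 of the 3 values shown sit. The compounds shown leave open whether methoxy and methyl differ at all on this read-out, and at what concentration, if any, these compounds would reach half-maximal inhibition.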